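Methyl in Place of Methoxy in a Weakly Active Series

The source may hold more compounds than are shown below. What is called first, only, known or untested is meant among the compounds shown, and "the series" means these compounds.

Of the compounds shown here, three have been measured in a functional assay, with a stated time of 150 min, tested at 15 ug/mL; a higher number here means a stronger effect of the compound at the concentration tested, a lower number a weaker effect. Compound 1 `COC(=O)c1c(Nc2ccc(Cl)cc2)sc(C(=O)c2ccc(OC)cc2)c1C` is reported as "not active" (no number reported), and compound 2 `COc1ccc(C(=O)c2sc(Nc3ccc(F)cc3)c(C(=O)O)c2C)cc1` gives 1.98%. Among the measured compounds shown here, compound 3 `COc1ccc(C(=O)c2sc(Nc3ccc(Cl)cc3)c(C(=O)O)c2C)cc1` is likewise reported as "not active" (no number reported), so no number places it on the scale; it shares that outcome with compound 1, and compound 2 is the only compound here with a figure at all. Compound 4 `Cc1ccc(C(=O)c2sc(Nc3ccc(Cl)cc3)c(C(=O)O)c2C)cc1` differs from compound 3 by a single change: methyl in place of methoxy on an aromatic carbon. For the measured compounds named here, nothing measured so far separates 4-methoxyphenyl from 4-methylphenyl, so no direction can be assigned to this step, and any shift in this assay is expected to stay within the scatter. Compound 4 is expected to give about 3% in this assay, within a range from 0% to 15%, with a fair chance of being reported without a number.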

Compound 4, a percentage reported as activity, at one concentration (the size of the read-out at that concentration, not a potency): "not active" (no number reported)
No number was reported for compound 4; the estimate stays without a comparison.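

Compound 3 and compound 4 both stand without a number in this assay, so no step can be read from 4-methoxyphenyl to 4-methylphenyl. No evidence bears on this result. The compounds shown leave open whether these two groups differ at all in this assay.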